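The source may report more compounds than this note shows. Statements on the series, on what has been measured and on what is new or still open speak of the compounds shown alone.

Three compounds sharing one core have been measured in an assay on isolated protein for inhibition of protein kinase C zeta type (Homo sapiens), with a stated time of 4 min; on this read-out higher numbers stand for weaker inhibition and lower numbers for stronger inhibition:

- compound 1, `CC(C)(C)C1=NN(c2ccc(F)cc2)C(c2ccc(O)cc2)C1`: 9400 nM
- compound 2, `CC(C)(C)C1=NN(c2cccc(Cl)c2)C(c2ccc(O)cc2)C1`: 5200 nM
- compound 3, `CC(C)(C)C1=NN(c2cccc(F)c2)C(c2ccc(O)cc2)C1`: 2200 nM

Compound 3 gives the lowest number of the three, and its lead is beyond the usual scatter in both directions: a 4.3-fold lower number from compound 1 to compound 3 (0.63 log units; beyond the scatter) and a 2.4-fold lower number from compound 2 to compound 3 (0.37 log units; beyond the scatter). Moving the fluorine from the para to the meta position of the phenyl ring on the ring nitrogen brought a modest gain, and swapping chlorine for fluorine at that meta position brought another. The step from compound 1 to compound 2 is within the scatter.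

Compound 4, `Cc1cccc(N2N=C(C(C)(C)C)CC2c2ccc(O)cc2)c1`, keeps the meta substituent but changes its identity: methyl in place of fluoro on an aromatic carbon. Going by the values given here, only one measured step touches this same aromatic carbon, the halogen swap from compound 2 to compound 3, and no measured step replaces a halogen by a carbon group. That one step was modest, and its direction gives no guide for methyl. The expected step in this assay is therefore small, likely within the scatter, with no firm direction: a 1.4-fold higher number from compound 3 to compound 4 (0.13 log units; within the scatter). Compound 4 is estimated at 3000 nM, within a range of 1000 nM to 9000 nM.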

Compound 4, half-maximal inhibitory concentration: 3500 nM
Compound 4: middle estimate off by 1.2-fold (0.07 log units), on the low side, and the stated range covers the measured number.
By their numbers in this assay, from the lowest: compounds 3, 4, 2 and 1 (each within the scatter of the next, the first and the last beyond it).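

In this assay, going by these compounds alone, methyl, the first carbon group at this aromatic carbon, cannot be told apart from fluoro (a 1.6-fold higher number from compound 3 to compound 4 (0.20 log units; within the scatter)) or from chloro (a 1.5-fold lower number from compound 2 to compound 4 (0.17 log units; within the scatter)). Fluoro and chloro are separated by more than the scatter, yet methyl lies within the scatter of both, so this change gives no clear gain or loss. The 3-methylphenyl group does keep a modest advantage over 4-fluorophenyl (a 2.7-fold lower number from compound 1 to compound 4 (0.43 log units; beyond the scatter)), as 3-fluorophenyl does, while 3-chlorophenyl in compound 2 stays within the scatter of compound 1 and so does not share it.

From the compounds shown here alone, whether a larger group here, such as ethyl, methoxy, trifluoromethyl or an amine, would shift the number beyond the scatter remains open. No measurement at hand bears on the reason for these numbers.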